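Replacing a pyrazole by its methylated isomer

The compounds below may be only part of what the source reports. "The series", "measured", "known", "first", "only" and "open" are said of these compounds alone.

Compound 1, `Cc1n[nH]cc1-c1cccc2c1CCC2c1ncc[nH]1`: 902 nM in a functional assay on CHO cells for agonist activity at Alpha-1B adrenergic receptor (Homo sapiens), read by FLIPR and calcium flux; a lower number here means that less compound is needed, a higher number that more compound is needed for the effect
Compound 3, `c1cc(-c2ccn[nH]2)c2c(c1)C(c1ncc[nH]1)CC2`: 600 nM in this assay
Compound 2, `c1ccc(-c2cccc3c2CCC3c2ncc[nH]2)nc1`: > 10000 nM in this assay, which is a limit of the assay and not a number

Compound 1 and compound 3 sit close together, the step of a 1.5-fold lower number from compound 1 to compound 3 (0.18 log units; within the scatter) lying within the scatter. Compound 2 gave only a limit (the limit of > 10000 nM in this assay, at which 1 of the 3 values shown sits).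

Compound 4, `Cn1ccc(-c2cccc3c2CCC3c2ncc[nH]2)n1`, differs from compound 1 in one place: 1-methyl-1H-pyrazol-3-yl in place of 3-methyl-1H-pyrazol-4-yl on an aromatic carbon. For the measured compounds named here, two measured steps bear on this. Swapping one pyrazole bearing a ring hydrogen for another left the number nearly unchanged, as in a 1.5-fold lower number from compound 1 to compound 3 (0.18 log units; within the scatter). Swapping to a pyridine, which like the entering group offers no hydrogen-bond donor, gave an at least 11-fold higher number from compound 1 to compound 2 (1.04 log units; beyond the scatter), and the reverse at least 16-fold lower number from compound 2 to compound 3 (1.22 log units; beyond the scatter). The entering 1-methyl-1H-pyrazol-3-yl has no hydrogen-bond donor and two acceptors, which places it closer to the pyridine case. A rise in the this assay number is therefore expected, though smaller than for compound 2 seems possible.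

For compound 4 the estimate is 3500 nM, between 800 nM and 15000 nM, an expected step of a 3.9-fold higher number from compound 1 to compound 4 (0.59 log units; beyond the scatter).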

Compound 4, half-maximal effective concentration: > 10000 nM
Compound 4 gave a limit, no number (the forecaster's own chance of this, stated with the estimate: 30%); middle value at least 2.8-fold (0.45 log units) away from the limit.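

In this assay, the new group gives an at least 11-fold higher number from compound 1 to compound 4 (1.04 log units; beyond the scatter), and an at least 16-fold higher number from compound 3 to compound 4 (1.22 log units; beyond the scatter), even though it has the same atoms and the same kind of ring as the 3-methyl-1H-pyrazol-4-yl it replaces. So having a pyrazole on this aromatic carbon is not enough: among the compounds shown, only compound 1 and compound 3, whose groups carry a hydrogen-bond donor, give a number, and no compound shown goes against this. Compound 2 and compound 4 each gave only a limit, and the step between them cannot be read: the limit of > 10000 nM in this assay, at which 2 of the 4 values shown sit.

Compound 4 loses the donor while its methyl group and its ring attachment also change, so the compounds shown cannot separate these changes. Going by these compounds, it also remains open whether another donor-bearing group on this carbon, such as a primary amine or a carboxylic acid, would give a measurable number.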